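A few compounds are considered here, and "the series" means these few. Any claim that something is new, unique, unknown or untested is made for them only; others in the source may bear on it.

Measured in a functional assay on MCF7 cells (Homo sapiens) for antiproliferative activity, with a stated time of 96 h; on this read-out higher numbers stand for weaker inhibition and lower numbers for stronger inhibition:
- compound 1 `Cc1cc(=O)oc2cc(OCC(=O)c3cc(C(F)(F)F)cc(C(F)(F)F)c3)ccc12`: 470 nM
- compound 2 `O=C(COc1ccc2c(C(F)(F)F)cc(=O)oc2c1)c1cc(C(F)(F)F)cc(C(F)(F)F)c1`: "not active" (no number reported)
- compound 3 `COc1cccc(C(=O)COc2ccc3c(C(F)(F)F)cc(=O)oc3c2)c1`: "not active" (no number reported)

Only compound 1 has a number on this read-out. Compound 3 has none: in this assay compound 3 is reported as "not active" (no number reported), and so is compound 2, which shares its core. Compound 3 therefore cannot be placed on the scale, only in the group without a measurable result.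

Compound 4 `CC(C)(C)C(=O)COc1ccc2c(C(F)(F)F)cc(=O)oc2c1` keeps that same core. For the measured compounds named here, the one structural change is tert-butyl in place of 3-methoxyphenyl on a carbonyl carbon, in words tert-butyl in place of 3-methoxyphenyl on a carbonyl carbon.

Without a number for compound 3, the size of this step cannot be read from the data. No clear gain is expected in this assay, and the most likely result is again a report without a number. If a number does appear, it is expected to show weaker inhibition than that of compound 1. For compound 4 the estimated value is 5000 nM, with an expected range from 800 nM to 30000 nM.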

Compound 4, half-maximal inhibitory concentration: "not active" (no number reported)
The entry for compound 4 holds no number, so the estimate cannot be set against anything.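

For the compounds shown here, compound 4, like compound 3, is reported as not active without a number, so no step between them can be read. The compounds shown leave open whether any group on that carbonyl carbon gives a measurable result with this shared core. No measured evidence bears on this outcome.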